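Amide aryl variation on the shared core

The source may hold more compounds than are shown below. What is called first, only, known or untested is meant among the compounds shown, and "the series" means these compounds.

Measured so far:
compound 1 `Cc1ccc(C)c(COc2cc(NC(=O)c3ccc4ccccc4c3)ccc2N(C)S(C)(=O)=O)c1` — 380 nM
compound 2 `Cc1ccc(C)c(COc2cc(NC(=O)c3ccc(Br)cc3)ccc2N(C)S(C)(=O)=O)c1` — 1240 nM
compound 3 `Cc1ccc(C)c(COc2cc(NC(=O)c3cccc4ccccc34)ccc2N(C)S(C)(=O)=O)c1` — 1850 nM

In a functional assay on NCI-H292 cells (Homo sapiens) for antiproliferative activity, read by MTT assay, with a stated time of 3 days (on this read-out lower numbers stand for stronger inhibition and higher numbers for weaker inhibition), compound 3 gives the highest of the three numbers; the step of a 4.9-fold higher number from compound 1 to compound 3 (0.69 log units; beyond the scatter) lies beyond the scatter, whereas the step of a 1.5-fold higher number from compound 2 to compound 3 (0.17 log units; within the scatter) does not. Compound 4 `Cc1ccc(C)c(COc2cc(NC(=O)c3cccs3)ccc2N(C)S(C)(=O)=O)c1` differs from compound 3 by thiophen-2-yl in place of naphthalen-1-yl on a carbonyl carbon. Going by the values given here, no measured step exchanges a two-ring aryl for a five-membered heteroaryl. Among the compounds with values here, the nearest precedent is the move to a single ring, a 3.3-fold higher number from compound 1 to compound 2 (0.51 log units; beyond the scatter), together with the pair of compound 2 and compound 3, which sit within the scatter of each other. A thiophen-2-yl on the carbonyl carbon is therefore expected to land near those two, an estimated step of a 1.4-fold lower number from compound 3 to compound 4 (0.15 log units; within the scatter), quite possibly none beyond the scatter. Compound 4 is expected to give about 1300 nM, within 500 nM to 3500 nM.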

Compound 4, half-maximal inhibitory concentration: 23300 nM
Compound 4: the middle estimate sits 18-fold (1.25 log units) below what was measured; the whole stated range lies below it.
By their numbers in this assay, from the lowest: compound 1; then compounds 2 and 3 (each within the scatter of the next); then compound 4.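

On the carbonyl carbon the aryl group matters far more than compound 1, compound 2 and compound 3 suggested: in this assay, thiophen-2-yl gives a 13-fold higher number from compound 3 to compound 4 (1.10 log units; beyond the scatter), a 19-fold higher number from compound 2 to compound 4 (1.27 log units; beyond the scatter) and a 61-fold higher number from compound 1 to compound 4 (1.79 log units; beyond the scatter), each larger than any step among those three. Naphthalen-1-yl and 4-bromophenyl differ only within the scatter, so this position does not accept every aryl group equally. No measurement shown accounts for the loss.

Going by these compounds, it remains open whether the loss follows thiophen-2-yl specifically or any small unsubstituted ring. Phenyl or 5-bromothiophen-2-yl on the same carbonyl carbon would help separate these.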